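Series notes: phenylsulfanyl to methylsulfonyl on two cores

The source may hold more compounds than are shown below. What is called first, only, known or untested is meant among the compounds shown, and "the series" means these compounds.

Measured so far, in a functional assay on BXPC-3 cells (Homo sapiens) for antiproliferative activity, read by MTT assay, with a stated time of 24 h; a higher number here means a weaker inhibitor, a lower number a stronger inhibitor:
compound 1, `CCN(CC)CCNC(=O)c1ccc(C(CC)(CC)c2ccc(OCSc3ccccc3)c(C)c2)n1CC`, gives 5670 nM.
compound 2, `CCN(CC)CCNC(=O)c1ccc(C(CC)(CC)c2ccc(OCS(C)(=O)=O)c(C)c2)n1CC`, gives 33700 nM.
compound 3, `CCN(CC)CCNC(=O)c1cc(C(CC)(CC)c2ccc(OCSc3ccccc3)c(C)c2)cn1CC`, gives 5370 nM.

Compound 1 and compound 2 differ by methylsulfonyl in place of phenylsulfanyl on a saturated chain carbon bound to an oxygen on an aromatic ring; this change made a 5.9-fold higher number from compound 1 to compound 2 (0.77 log units; beyond the scatter). Compound 3 has the same atoms as compound 1, joined differently; the difference between the two cores is not broken down here. In this assay compound 3 and compound 1 lie within the scatter of each other, so the two cores read alike.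

Compound 4, `CCN(CC)CCNC(=O)c1cc(C(CC)(CC)c2ccc(OCS(C)(=O)=O)c(C)c2)cn1CC`, is not yet measured. It differs from compound 3 by methylsulfonyl in place of phenylsulfanyl on a saturated chain carbon bound to an oxygen on an aromatic ring, the same change at the same place as that between compound 1 and compound 2. The step is expected to be of about the earlier size, a 5.8-fold higher number from compound 3 to compound 4 (0.76 log units; beyond the scatter), because a 5.9-fold higher number from compound 1 to compound 2 (0.77 log units; beyond the scatter) was seen on a core that reads like compound 3. Compound 4 is therefore estimated at 31000 nM, likely between 14000 nM and 70000 nM.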

Compound 4, half-maximal inhibitory concentration: 30400 nM
The estimate for compound 4 lay 1.0-fold (0.01 log units) above the measured number; the range from low to high includes it.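

The step in this assay for methylsulfonyl in place of phenylsulfanyl is a 5.7-fold higher number from compound 3 to compound 4 (0.75 log units; beyond the scatter) and matches the step on the other core: the same change on two cores in this assay, a 5.9-fold higher number (0.77 log units; beyond the scatter) from compound 1 to compound 2 and a 5.7-fold higher number (0.75 log units; beyond the scatter) from compound 3 to compound 4, 1.0-fold (0.02 log units) apart, within the scatter of two such steps.

The change therefore carried over with no readable difference in size between these two cores, which already read alike with phenylsulfanyl in place. This pair does not show that the step would hold on a core that reads differently, and it does not say why the change weakens the read-out.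

The compounds shown leave open whether the step follows from losing the phenyl ring or from going from sulfanyl to sulfonyl. Phenylsulfonyl and methylsulfanyl at the same place would separate these two parts.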